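The compounds below may be only part of what the source reports. "The series", "measured", "known", "first", "only" and "open" are said of these compounds alone.

Compound 3 `CCCn1nccc1-c1ccccc1NCC1=NCCN1` carries the propyl group on the aromatic nitrogen of the shared core. In an in vitro functional assay on cells (Fibroblast) for agonist activity at Alpha-1D adrenergic receptor (Homo sapiens) (a higher number here means that more compound is needed for the effect, a lower number that less compound is needed), compound 3 gives only a limit, < 100000 nM. Compound 1 `Cn1nccc1-c1ccccc1NCC1=NCCN1` also gives a limit in this assay, < 100000 nM. Compound 2 `CCn1nccc1-c1ccccc1NCC1=NCCN1` gives a limit in this assay as well, < 100000 nM. With the limit of < 100000 nM in this assay, at which 3 of the 3 values shown sit, the steps a step that the two limits leave unreadable from compound 1 to compound 2, a step that the two limits leave unreadable from compound 1 to compound 3 and a step that the two limits leave unreadable from compound 2 to compound 3 have no readable size. Compound 4 `CC(C)n1nccc1-c1ccccc1NCC1=NCCN1` differs from compound 3 by isopropyl in place of propyl on an aromatic nitrogen. The measured steps concern chain lengthening, not branching, and none is readable, so no direction can be drawn from them. Compound 4 is expected to be reported at the same limit. The expected step is a step that the limit leaves unreadable from compound 3 to compound 4. Compound 4 is estimated at 10000 nM, ranging from 1000 nM to 100000 nM.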

Compound 4, half-maximal effective concentration: < 100000 nM
Compound 4 ended at the assay's limit (the forecaster's own chance of this, stated with the estimate: 70%); the middle value lies beyond the limit too.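

No step among compound 1, compound 2, compound 3 and compound 4 can be read, because each value is only a limit: the limit of < 100000 nM in this assay, at which 4 of the 4 values shown sit.

The compounds shown leave open whether propyl and isopropyl differ at all in this assay.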